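The compounds below may be only part of what the source reports. "The series", "measured", "known", "first", "only" and "open" are said of these compounds alone.

In a functional assay on PC-3 cells (Homo sapiens) for inhibition, read by sulforhodamine B assay, with a stated time of 48 h (a higher number here means a weaker inhibitor of growth, a lower number a stronger inhibitor of growth), three compounds built on the shared core have been measured so far. Compound 1 (`CC1(/C=C/c2ccc(C(F)(F)F)cc2)C=CC(=O)O1`) gives 13100 nM, the lowest of the three numbers. Compound 2 (`COc1ccc(/C=C/C2(C)C=CC(=O)O2)c(OC)c1OC`) gives 90000 nM and compound 3 (`COc1cc(OC)c(OC)cc1/C=C/C1(C)C=CC(=O)O1`) gives 184000 nM, and both stand higher than compound 1 by more than the scatter.

Compound 4 (`COc1ccc(/C=C/C2(C)C=CC(=O)O2)cc1`) has not yet been measured. Its difference from compound 1 is methoxy in place of trifluoromethyl on an aromatic carbon, in words methoxy in place of trifluoromethyl on an aromatic carbon. Going by the values given here, no measured pair isolates this change, so the guide is indirect. The two measured compounds that carry methoxy groups are compound 2 at 90000 nM and compound 3 at 184000 nM, and neither reaches the number of compound 1. A moderate step toward a higher number is therefore expected in this assay, probably beyond the scatter, though a smaller one cannot be excluded. The expected step is a 3.1-fold higher number from compound 1 to compound 4 (0.48 log units; beyond the scatter). For compound 4 the estimated value is 40000 nM, with an expected range of 15000 nM to 110000 nM.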

Compound 4, concentration for total growth inhibition: 145000 nM
Compound 4: the middle estimate sits 3.6-fold (0.56 log units) below what was measured; measured number outside the range, above it.
By their numbers in this assay, from the lowest: compound 1; then compounds 2, 4 and 3 (each within the scatter of the next, the first and the last beyond it).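

In this assay, going by these compounds alone, the pair of compound 1 and compound 4 gives the first direct reading of this position: methoxy in place of trifluoromethyl on an aromatic carbon is a large step, an 11-fold higher number from compound 1 to compound 4 (1.04 log units; beyond the scatter). Within the data shown here, the comparison with the other methoxy-bearing compounds was indirect, whereas this pair changes only the one group and shows how much the exchange alone moves the number. Nothing available explains the size of this step.

One pair cannot show whether the step reflects the loss of trifluoromethyl, the arrival of methoxy, or both. Going by these compounds, a nitrile, a chlorine atom or an amine on the same aromatic carbon would help separate these readings, and whether the step carries over to other positions on the aromatic ring remains open.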